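Amide nitrogen substituent: step from compound 3 to compound 4

This account rests on a few compounds, and the source may have more. Where it says the series, first, only, none or still open, it means among the compounds named here.

Three members of the series carry the shared core with an aryl group on the amide-type nitrogen. Compound 1 `O=C(CCC(=O)OCCCCCCSc1ccc([N+](=O)[O-])c2nonc12)Nc1ccccc1` bears unsubstituted phenyl and in an assay on isolated protein for inhibition of glutathione S-transferase P (Homo sapiens), with a stated time of 10 min (on this read-out lower numbers stand for stronger inhibition and higher numbers for weaker inhibition), compound 1 gives 10200 nM. Compound 2 `COc1ccccc1NC(=O)CCC(=O)OCCCCCCSc1ccc([N+](=O)[O-])c2nonc12` gives 4050 nM, and compound 3 `O=C(CCC(=O)OCCCCCCSc1ccc([N+](=O)[O-])c2nonc12)Nc1ccc(C(F)(F)F)cc1` gives 5050 nM. The two substituted aryls each improve on the parent: a 2.5-fold lower number from compound 1 to compound 2 (0.40 log units; beyond the scatter) and a 2.0-fold lower number from compound 1 to compound 3 (0.31 log units; beyond the scatter), both modest but beyond the scatter. Between the two substituted aryls the difference is a 1.2-fold higher number from compound 2 to compound 3 (0.10 log units; within the scatter), so compound 3 sits second highest of the three numbers, indistinguishable from compound 2 and separated from compound 1 only by a modest step.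

Compound 4 `O=C(CCC(=O)OCCCCCCSc1ccc([N+](=O)[O-])c2nonc12)NCCN1CCCC1` replaces the aryl altogether: 2-(pyrrolidin-1-yl)ethyl in place of 4-(trifluoromethyl)phenyl on an amide-type nitrogen. Within the data shown here, no measured step bears directly on this change; the only swap on the amide-type nitrogen, compound 2 to compound 3, is aryl for aryl and lies within the scatter, while the steps from compound 1 concern substituents on an aromatic carbon that stays in place. Among the measured compounds shown here, with no precedent for leaving the aromatic ring, the expected step of a 1.4-fold higher number from compound 3 to compound 4 (0.14 log units; within the scatter) is set at no change beyond the scatter, with a wide range. For compound 4 the estimate in this assay is 7000 nM, between 2500 nM and 20000 nM.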

Compound 4, half-maximal inhibitory concentration: 460 nM
Compound 4: the middle estimate sits 15-fold (1.18 log units) above what was measured; measured number outside the range, below it.
By their numbers in this assay, from the lowest: compound 4; then compounds 2 and 3 (each within the scatter of the next); then compound 1.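

On the amide-type nitrogen, aryl-for-aryl change had not separated compounds beyond the scatter, and substituents on the phenyl gave only modest steps (a 2.5-fold lower number from compound 1 to compound 2 (0.40 log units; beyond the scatter) and a 2.0-fold lower number from compound 1 to compound 3 (0.31 log units; beyond the scatter)), whereas leaving the aryl groups altogether moves the number much further. The new group gives an 11-fold lower number from compound 3 to compound 4 (1.04 log units; beyond the scatter), together with an 8.8-fold lower number from compound 2 to compound 4 (0.94 log units; beyond the scatter) and a 22-fold lower number from compound 1 to compound 4 (1.35 log units; beyond the scatter), which makes compound 4 the strongest of the four in this assay and shows this position to be far more responsive to the type of group on the nitrogen than to decoration of an aryl ring. The change swaps an aromatic carbon ring for a two-carbon-linked non-aromatic ring holding a nitrogen, so several features differ at once, and nothing available here accounts for the gain.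

Open, on these data alone, is whether the gain follows the ring nitrogen or only the loss of the aryl group: 2-cyclopentylethyl, with carbon in place of that nitrogen, would separate the two. Also open, as far as these compounds go, are the effects of an open-chain amine such as 2-(dimethylamino)ethyl and of a longer chain such as 3-(pyrrolidin-1-yl)propyl.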